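From furan-2-yl to benzyloxy on a carbonyl carbon

The compounds below may be only part of what the source reports. "The series", "measured", "known", "first", "only" and "open" are said of these compounds alone.

In a functional assay on L5178Y cells (Mus musculus) for inhibition, read by MTT assay, with a stated time of 24 h (on this read-out higher numbers stand for weaker inhibition and lower numbers for stronger inhibition), compound 1 `Oc1ccc([C@@H]2C/C(=N\Nc3ccc(Br)cn3)c3c(O)cc(O)cc3O2)cc1` gives >= 11300 nM, which is a limit and not a number. Compound 2 `O=C(N/N=C1\C[C@@H](c2ccc(O)cc2)Oc2cc(O)cc(O)c21)c1ccco1` gives >= 11300 nM, which is also a limit. Compound 2 therefore has no exact value to start from, and neither does anything else measured so far: the limit of >= 11300 nM in this assay, at which 2 of the 2 values shown sit.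

Compound 3 `O=C(N/N=C1\C[C@@H](c2ccc(O)cc2)Oc2cc(O)cc(O)c21)OCc1ccccc1` keeps the core of compound 2 and changes one group: benzyloxy in place of furan-2-yl on a carbonyl carbon. Benzyloxy stands in place of furan-2-yl on a carbonyl carbon, so the (furan-2-yl)carbonyl becomes a benzyloxycarbonyl.

Going by the values given here, only one measured step bears on this change: a step that the two limits leave unreadable from compound 1 to compound 2. It has no readable size, so it offers no amount or direction to carry over. All it shows is that two different groups both left the read-out at the limit. No step beyond the scatter is therefore expected in this assay, and no direction can be favoured. The expected change is a step that the limit leaves unreadable from compound 2 to compound 3. A report of only a limit would be the likeliest outcome. For compound 3 the estimated value is 12000 nM, with an expected range of 5000 nM to 25000 nM.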

Compound 3, half-maximal inhibitory concentration: >= 11300 nM
Compound 3: a limit, no number; the forecaster's own chance of this, stated with the estimate: 70%; the middle value does not contradict the limit.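

In this assay compound 3 gives >= 11300 nM and this is a limit, not a number. Going by these compounds alone, compound 1 and compound 2 also stand at limits, so no step among the three compounds can be read. The compounds shown leave open how strongly any of them inhibits, and whether changing the group on the shared core alters that at all.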